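A few compounds are considered here, and "the series" means these few. Any claim that something is new, unique, unknown or untested is made for them only; others in the source may bear on it.

Compound 1, `O=C1N=C(N2N=C(c3ccccc3)CC2c2ccccc2O)S/C1=C1/C(=O)Nc2ccccc21`, was tested in a functional assay on cells (Leukemia cell, Homo sapiens) for cytotoxicity, read by sulforhodamine B assay, with a stated time of 48 h (on this read-out lower numbers stand for stronger inhibition of growth and higher numbers for weaker inhibition of growth), where compound 1 gives 48800 nM. Compound 2, `O=C1N=C(N2N=C(c3ccccc3)CC2c2ccccc2O)S/C1=C1/C(=O)Nc2ccc(Br)cc21`, differs from compound 1 in a single place: bromo in place of hydrogen on an aromatic carbon. In this assay compound 2 gives 1050 nM, and the step is a 46-fold lower number from compound 1 to compound 2 (1.67 log units; beyond the scatter). Compound 3, `COc1ccc(C2CC(c3ccc4ccccc4c3)=NN2C2=NC(=O)/C(=C3\C(=O)Nc4ccccc43)S2)cc1`, rests on a different core; how the core of compound 3 differs from the core of compound 1 is not broken down here. In this assay, among the compounds with values here, compound 3 gives 59600 nM, a number that lies close to the one for compound 1 and far from the one for compound 2. Compound 4, `COc1ccc(C2CC(c3ccc4ccccc4c3)=NN2C2=NC(=O)/C(=C3\C(=O)Nc4ccc(Br)cc43)S2)cc1`, is the not yet measured partner of compound 3 and carries the same change that links compound 1 to compound 2: bromo in place of hydrogen on an aromatic carbon. The place of the change is described in the same words for both pairs, so it is the same change on a different core. Because of the step of a 46-fold lower number from compound 1 to compound 2 (1.67 log units; beyond the scatter) seen on the core of compound 1, a step of a broadly similar but somewhat smaller size is expected for compound 4 in this assay, namely a 24-fold lower number from compound 3 to compound 4 (1.38 log units; beyond the scatter), since a single measured pair on another core is thin support. Compound 4 is therefore estimated at 2500 nM in this assay, with the expected range running from 600 nM to 15000 nM.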

Compound 4, concentration for total growth inhibition: 3370 nM
Compound 4: the middle estimate sits 1.3-fold (0.13 log units) below what was measured, within the range that was stated.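

In this assay, bromo in place of hydrogen on an aromatic carbon again gives a large step on the second core, an 18-fold lower number from compound 3 to compound 4 (1.25 log units; beyond the scatter), and it runs the same way as the step on the core of compound 1. Set side by side, the two steps cannot be told apart in size, so in this small set the change carries over from one core to the other: the same change on two cores in this assay, a 46-fold lower number (1.67 log units; beyond the scatter) from compound 1 to compound 2 and an 18-fold lower number (1.25 log units; beyond the scatter) from compound 3 to compound 4, 2.6-fold (0.42 log units) apart, within the scatter of two such steps. This shows a transfer across two cores, at one place on the molecule and in one read-out; it does not show that the step would hold on a third core, it does not rank the two cores by how much they gain, and it gives no reason why the change acts as it does.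

The compounds shown leave open whether another group on the same aromatic carbon, such as chloro, methyl or an amine, would give a step of similar size. They also leave open which of the several differences between the core of compound 1 and the core of compound 3 matter, and whether the step would persist in cells other than leukemia cells.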